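From 4-hydroxy-3-methoxyphenyl to 4-nitrophenyl on a shared core

The source may hold more compounds than are shown below. What is called first, only, known or untested is meant among the compounds shown, and "the series" means these compounds.

Compound 1 `COc1cccc(/C=C/C(=O)N2Cc3ccccc3[C@@H](OCc3ccccc3)[C@@H]2CO)c1OC` gives 55100 nM
Compound 2 `COc1cc(/C=C/C(=O)N2Cc3ccccc3[C@@H](OCc3ccccc3)[C@@H]2CO)ccc1O` gives 37300 nM

Both compounds were tested in a functional assay on MCF7 cells (Homo sapiens) for antiproliferative activity, read by MTT assay, with a stated time of 48 h; a lower number here means a stronger inhibitor, a higher number a weaker inhibitor. There compound 2 gives 37300 nM and sits within the usual scatter of compound 1 (55100 nM), so the two numbers cannot be told apart.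

The next compound is compound 3 `O=C(/C=C/c1ccc([N+](=O)[O-])cc1)N1Cc2ccccc2[C@@H](OCc2ccccc2)[C@@H]1CO`, which differs from compound 2 in one place (4-nitrophenyl in place of 4-hydroxy-3-methoxyphenyl on a double-bonded chain carbon bound to a double-bonded chain carbon). The core stays the same, and only the group on the double-bonded chain carbon changes. Just one measured step bears on this swap (a 1.5-fold lower number from compound 1 to compound 2 (0.17 log units; within the scatter)). It also exchanges one phenyl group for another at that place, and it stayed within the scatter. Within the data shown here, no measured compound carries a 4-nitrophenyl group, so this evidence is thin and the range must stay wide.

On that basis, no shift beyond the scatter is expected in this assay, and the expected step is small (a 1.1-fold higher number from compound 2 to compound 3 (0.03 log units; within the scatter)). For compound 3 the estimated value is 40000 nM and the expected range runs from 15000 nM to 90000 nM in this test.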

Compound 3, half-maximal inhibitory concentration: 24400 nM
The estimate for compound 3 lay 1.6-fold (0.21 log units) above the measured number; low and high end bracket the measured number.
By their numbers in this assay, from the lowest: compounds 3, 2 and 1 (each within the scatter of the next, the first and the last beyond it).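

In this assay, the place on the double-bonded chain carbon accepts 4-nitrophenyl, a group with no hydrogen-bond donor, in place of 4-hydroxy-3-methoxyphenyl, and the result (a 1.5-fold lower number from compound 2 to compound 3 (0.18 log units; within the scatter)) leaves the two numbers impossible to tell apart. Set against 2,3-dimethoxyphenyl, however, the same group gives the first step at this place that passes the usual scatter (a 2.3-fold lower number from compound 1 to compound 3 (0.35 log units; beyond the scatter)), although it is only a modest one and compound 2 cannot be separated from either of the other two compounds. Nothing measured on these compounds speaks to what lies behind that modest shift.

All three groups shown at this place are substituted phenyl rings, so it stays open whether an amine, a carboxylic acid or a longer chain in place of the ring would keep the number in this range or move it. It also stays open whether the nitro group itself matters here, since plain unsubstituted phenyl is not among the compounds shown and could give a number close to that of compound 3.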